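Iridoid glycoside esters: hydroxy added on the cyclohexyl ring

The source may report more compounds than this note shows. Statements on the series, on what has been measured and on what is new or still open speak of the compounds shown alone.

Working notes on a small set of esters of a shared glycoside core. Compound 1 is `COc1cc([C@@H]2Oc3c(O)cc(/C=C/C(=O)O[C@@H]4C[C@](C)(O)[C@H]5[C@H](O[C@@H]6O[C@H](CO)[C@@H](O)[C@H](O)[C@H]6O)OC=C[C@H]54)cc3[C@H]2CO)ccc1O`. In a functional assay on A549 cells (Homo sapiens) for cytotoxicity, read by MTT assay, with a stated time of 4 days (on this read-out lower numbers stand for stronger inhibition and higher numbers for weaker inhibition), compound 1 gives only a limit, > 10000 nM. Compound 2 is `CC(/C=C/[C@@]1(O)C(C)(C)CCC[C@@]1(C)O)=C\C(=O)O[C@@H]1C[C@](C)(O)[C@H]2[C@H](O[C@@H]3O[C@H](CO)[C@@H](O)[C@H](O)[C@H]3O)OC=C[C@H]21`. In this assay compound 2 likewise returns a limit rather than a number, > 10000 nM. Within the data shown here, compound 2 therefore stands at the limit of > 10000 nM in this assay, at which 2 of the 2 values shown sit, together with the only other value shown, and no ordering between the two can be read. Among the measured compounds shown here, no pair of measured compounds differs in a single place, so no measured step is available.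

Compound 3 is `CC(/C=C/[C@@]1(O)C(C)(C)C[C@H](O)C[C@@]1(C)O)=C\C(=O)O[C@@H]1C[C@](C)(O)[C@H]2[C@H](O[C@@H]3O[C@H](CO)[C@@H](O)[C@H](O)[C@H]3O)OC=C[C@H]21`, not yet measured in this assay. Its difference from compound 2 is hydroxy in place of hydrogen on a saturated ring carbon. Nothing shown on the measured compounds points toward a gain in this assay from such a change, as every value so far is a limit. The expected step in this assay is a step that the limit leaves unreadable from compound 2 to compound 3, that is, none beyond the usual scatter. Compound 3 is estimated at 20000 nM, with a range from 8000 nM to 60000 nM, and most probably again reported only as a limit.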

Compound 3, half-maximal inhibitory concentration: > 10000 nM
Compound 3 was reported as a limit (the forecaster's own chance of this, stated with the estimate: 85%); the middle value lies beyond the limit too.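

Compound 2 and compound 3 both return only a limit in this assay, so no step can be read for hydroxy in place of hydrogen on a saturated ring carbon: the limit of > 10000 nM in this assay, at which 3 of the 3 values shown sit.

The compounds shown leave open whether the 1,2,4-trihydroxy-2,6,6-trimethylcyclohexyl and 1,2-dihydroxy-2,6,6-trimethylcyclohexyl esters differ at all, and whether any ester of the shared core gives a readable value in this assay.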